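The source may hold more compounds than are shown below. What is called first, only, known or untested is meant among the compounds shown, and "the series" means these compounds.

- Compound 1 `Cc1c(O)nc(SCc2ccc(C#N)cc2)nc1Cc1c(Cl)cccc1Cl`: > 60000 nM
- Compound 2 `Cc1c(O)nc(SCc2ccc(Cl)cc2)nc1Cc1c(Cl)cccc1Cl`: > 59000 nM
- Compound 3 `Cc1c(O)nc(SCc2ccccc2)nc1Cc1c(Cl)cccc1Cl`: > 64000 nM

In a functional assay on MT4 cells (Homo sapiens) for cytotoxicity, read by MTT assay (on this read-out higher numbers stand for lower toxicity in this test and lower numbers for higher toxicity in this test), compound 1 gives > 60000 nM, which is a limit and not a number. Compound 2 gives > 59000 nM, also a limit. Compound 3 gives > 64000 nM, again a limit. Compound 1 therefore cannot be ranked against the other two.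

Compound 4 `Cc1c(O)nc(SCc2ccc(C#N)cc2)nc1Cc1c(F)cccc1F` departs from compound 1 by one change: 2,6-difluorophenyl in place of 2,6-dichlorophenyl on a saturated chain carbon bound to an aromatic carbon. The measured steps are a step that the two limits leave unreadable from compound 1 to compound 2, a step that the two limits leave unreadable from compound 1 to compound 3 and a step that the two limits leave unreadable from compound 2 to compound 3. All three keep the 2,6-dichlorophenyl group, so none tests this change, and none has a readable size. No step beyond the scatter is expected in this assay, in either direction. The expected change is a step that the limit leaves unreadable from compound 1 to compound 4. Compound 4 is estimated at 65000 nM, with an expected range of 30000 nM to 100000 nM.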

Compound 4, half-maximal cytotoxic concentration: > 65000 nM
Compound 4 was reported as a limit; the forecaster's own chance of this, stated with the estimate: 80%; the middle value lies on the limit itself.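

Going by these compounds alone, compound 1 and compound 4 are both reported as limits, so no step between them can be read. The compounds shown leave open whether 2,6-difluorobenzyl and 2,6-dichlorobenzyl differ at all in this assay.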